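The source may report more compounds than this note shows. Statements on the series, on what has been measured and on what is new or still open speak of the compounds shown alone.

Compound 2, with the structure `O=C(CSc1nnnn1-c1ccccc1)N/N=c1/scc(-c2ccccc2)n1-c1ccccc1`, is the starting point of this step. In a functional assay on C6 cells (Rattus norvegicus) for cytotoxicity, read by MTT assay, with a stated time of 24 h, tested at 25 ug/mL (a lower number here means a stronger effect, a higher number a weaker effect of the compound at the concentration tested), compound 2 gives 42.5%, which is the lower of the two numbers recorded so far. Its nearest neighbour is compound 1, the structure `O=C(CSc1nnnn1-c1ccccc1)N/N=c1/scc(-c2ccc(Br)cc2)n1-c1ccccc1`, which in this assay gives 47.9%; the two compounds differ only by hydrogen in place of bromo on an aromatic carbon, and the resulting step, a number 5.4 percentage points lower from compound 1 to compound 2 (within the scatter), falls within the scatter of the method.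

The unmeasured compound 3 has the structure `N#Cc1ccc(-c2cs/c(=N/NC(=O)CSc3nnnn3-c3ccccc3)n2-c2ccccc2)cc1`. It differs from compound 2 by cyano in place of hydrogen on an aromatic carbon. Among the measured compounds shown here, the single measured step touches the same aromatic carbon, and with a number 5.4 percentage points lower from compound 1 to compound 2 (within the scatter) it did not move the read-out beyond the scatter. On that basis the step from compound 2 to compound 3 in this assay is expected to stay within the scatter as well, amounting to a number 2.5 percentage points higher from compound 2 to compound 3 (within the scatter). Compound 3 is therefore estimated to give 45% in this assay, with a range from 32% to 58%.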

Compound 3, a percentage reported as activity, at one concentration (the size of the read-out at that concentration, not a potency): 64.2%
Compound 3: middle estimate off by 19.2 percentage points, on the low side; the whole stated range lies below it.
By their numbers in this assay, from the lowest: compounds 2 and 1 (each within the scatter of the next); then compound 3.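

In this assay, the aromatic carbon para to a large group proves not to be indifferent to what it carries: cyano in place of hydrogen gives a number 21.7 percentage points higher from compound 2 to compound 3 (beyond the scatter), and cyano in place of bromo gives a number 16.3 percentage points higher from compound 1 to compound 3 (beyond the scatter), whereas the exchange of bromo for hydrogen had stayed within the scatter, at a number 5.4 percentage points lower from compound 1 to compound 2 (within the scatter). The earlier pair therefore did not speak for every substituent at this carbon, since among the three groups shown only cyano separates from the others, and compound 3 shows the weakest effect at the concentration tested, with its steps to both other compounds beyond the scatter. Nothing available accounts for why cyano parts from bromo and hydrogen here.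

The three compounds leave open whether this shift belongs to cyano alone or would also appear with an amine, a carboxylic acid or a methoxy group on the same aromatic carbon. They also leave open whether cyano would have a comparable effect on another aromatic carbon of the shared core, and whether the shift would persist at other concentrations.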